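Chain extension at the shared core: cytotoxicity notes

This account rests on a few compounds, and the source may have more. Where it says the series, first, only, none or still open, it means among the compounds named here.

In a functional assay on G-361 cells (Homo sapiens) for cytotoxicity, read by sulforhodamine B assay (a higher number here means that more compound is tolerated, a lower number that less compound is tolerated), compound 2 `CCCCNc1nc(CC)nc2c1cnn2-c1ccccc1` sits at the limit of the assay, reported as > 100000 nM, which is a limit and not a number. Compound 1 `CCCCNc1nc(C)nc2c1cnn2-c1ccccc1` likewise gives only a limit in this assay, > 100000 nM. The step that the two limits leave unreadable from compound 1 to compound 2 cannot be sized, since both of its ends are limits (the limit of > 100000 nM in this assay, at which 2 of the 2 values shown sit). Compound 3 `CCCCNc1nc(C(C)C)nc2c1cnn2-c1ccccc1` is not yet measured in this assay; it differs from compound 2 by methyl in place of hydrogen on a saturated chain carbon bound to an aromatic carbon and a saturated chain carbon. Among the compounds with values here, the one measured step that bears on this change is that same unreadable step, which offers neither a direction nor a size. With both values shown resting at the limit, the expectation is that compound 3 also remains at the limit, with no step beyond the scatter in this assay, so the expected step that the limit leaves unreadable from compound 2 to compound 3 is essentially none. Compound 3 is therefore estimated at 150000 nM, within a range from 60000 nM to 500000 nM, and is most likely to come back as a limit rather than a number.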

Compound 3, concentration lethal to 50% of the cells: > 100000 nM
Compound 3 was reported as a limit (the forecaster's own chance of this, stated with the estimate: 85%); the middle value does not contradict the limit.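

No step can be read among compound 1, compound 2 and compound 3 in this assay, because all three results are limits and not numbers: the limit of > 100000 nM in this assay, at which 3 of the 3 values shown sit.

The compounds shown leave open whether methyl, ethyl and isopropyl on this aromatic carbon differ at all in cytotoxicity, and at what concentration any of the three would become lethal to these cells.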